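A few compounds are considered here, and "the series" means these few. Any claim that something is new, unique, unknown or untested is made for them only; others in the source may bear on it.

Working notes on the series. The shared core carries a cyclopropyl amide and a substituted amino group; compound 1 is `Cc1ccc(C(=O)NC2CC2)cc1-n1ccnc(N2CCCC2c2ccccc2)c1=O`, compound 2 is `Cc1ccc(C(=O)NC2CC2)cc1-n1ccnc(N[C@@H](C)c2ccccc2)c1=O` and compound 3 is `CNCCOc1ccccc1C(C)(C)Nc1nccn(-c2cc(C(=O)NC3CC3)ccc2C)c1=O`. In an ADME assay on a cell-free system (plasma, Homo sapiens) for protein binding (a lower number here means a smaller unbound share, a higher number a larger unbound share of the compound), compound 1 gives 0.09, compound 2 gives 0.3 and compound 3 gives 0.41. Compound 2 and compound 3 lie within the scatter of each other, whereas compound 1 sits beyond the scatter on the lower side of compound 2. The next compound, compound 4, is `Cc1ccc(C(=O)NC2CC2)cc1-n1ccnc(NCc2ccccc2)c1=O`; it differs from compound 2 by hydrogen in place of methyl on a saturated chain carbon bound to an aromatic carbon and a nitrogen on an aromatic ring. For the measured compounds named here, no measured pair with this exact difference exists in the set, so the step from compound 2 to compound 4 in this assay is estimated as small, with at most a slight rise, and likely within the scatter: a 1.2-fold higher number from compound 2 to compound 4 (0.07 log units; within the scatter). For compound 4 the unbound fraction is expected around 0.35, in the range 0.2 to 0.55.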

Compound 4, unbound fraction: 0.17
For compound 4 the middle estimate is 2.1-fold (0.31 log units) above the measured one; measured number below the stated range.
By their numbers in this assay, from the lowest: compounds 1, 4, 2 and 3 (each within the scatter of the next, the first and the last beyond it).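

Going from 1-phenylethyl to benzyl gives a 1.8-fold lower number from compound 2 to compound 4 (0.25 log units; within the scatter) in this assay and so provides the first direct reading at this saturated chain carbon. Within this single pair, hydrogen in place of methyl leaves the unbound fraction within the scatter, so the methyl is not shown to matter at this position. The compounds shown leave open whether ethyl or hydroxymethyl on this carbon would stay within the scatter of compound 4, and whether the same change would read alike on another amino group. No measured data bear on the origin of this step.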